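The source may report more compounds than this note shows. Statements on the series, on what has been measured and on what is new or still open speak of the compounds shown alone.

Compound 1 `O=C1CNc2nc(Nc3ccccc3)ncc2N1` is the unsubstituted parent of the series; in a functional assay on MDA-MB-231 cells (Homo sapiens) for cytotoxicity, read by MTT assay, with a stated time of 48 h (on this read-out higher numbers stand for weaker inhibition and lower numbers for stronger inhibition), compound 1 gives > 100000 nM, which is a limit of the assay and not a number. Compound 2 `O=C1CNc2nc(Nc3ccc(Cl)cc3)ncc2N1` carries a chloro group on the six-membered aromatic ring of carbon only, and in this assay compound 2 gives 41700 nM. For the measured compounds named here, the step of an at least 2.3-fold lower number from compound 1 to compound 2 (0.37 log units; beyond the scatter) is the one direct reading on a chloro-for-hydrogen change in this set. Compound 3 `CN1CC(=O)Nc2cnc(Nc3ccccc3)nc21` instead carries a methyl on a ring nitrogen of the shared core. In this assay compound 3 gives > 100000 nM, again a limit rather than a number. Hence a step that the two limits leave unreadable from compound 1 to compound 3 cannot be sized, and compound 3 stands only at the limit of > 100000 nM in this assay, at which 2 of the 3 values shown sit. Compound 4 `CN1CC(=O)Nc2cnc(Nc3ccc(Cl)cc3)nc21` is the analogue of compound 3 with the change (chloro in place of hydrogen on an aromatic carbon), the same change that took compound 1 to compound 2. Going by the values given here, only one measured step bears on it, an at least 2.3-fold lower number from compound 1 to compound 2 (0.37 log units; beyond the scatter), and since compound 3 starts from a limit, the expected value in this assay can be placed only loosely, near or somewhat beneath that limit. Compound 4 is therefore expected to show the step of an at least 2.2-fold lower number from compound 3 to compound 4 (0.34 log units; beyond the scatter) in this assay. The estimate for compound 4 in this assay is 45000 nM, with a range from 15000 nM to 100000 nM.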

Compound 4, half-maximal inhibitory concentration: > 100000 nM
Compound 4 gave a limit, no number; the forecaster's own chance of this, stated with the estimate: 35%; middle value at least 2.2-fold (0.34 log units) from the limit.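

For the compounds shown here, with the ring nitrogen carrying a methyl, the chloro group on the six-membered aromatic ring of carbon only gives no readable gain in this assay: both compound 3 and compound 4 sit at a limit, so the step between them cannot be read, and the reading from compound 1 to compound 2 finds no measured counterpart on the methylated core. The methyl change, unreadable on the unsubstituted pair, now has a lower bound on its size with the chloro group in place, as an at least 2.3-fold higher number from compound 2 to compound 4 (0.37 log units; beyond the scatter). Compound 2 remains the only compound here with a number rather than a limit: the limit of > 100000 nM in this assay, at which 3 of the 4 values shown sit.

Whether chloro for hydrogen does anything at all on the methylated core stays unsized, as does the methyl change in the absence of the chloro group. Also open, on these data alone, is whether an amine or a methoxy group in place of the chloro group, or a longer chain in place of the methyl on the ring nitrogen, would give a number rather than a limit in this assay.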